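The source may report more compounds than this note shows. Statements on the series, on what has been measured and on what is new or still open speak of the compounds shown alone.

Measured in a functional assay on HeLa cells (Homo sapiens) for antiproliferative activity, with a stated time of 48 h; a higher number here means a weaker inhibitor, a lower number a stronger inhibitor:
- compound 1 `C=C(Br)C(=O)Nc1ccc(C(=O)/C=C/c2ccc(OC)c(OC)c2OC)cc1` gives 510 nM
- compound 2 `COc1ccc(/C=C/C(=O)c2ccc(N)cc2)c(OC)c1` gives 22000 nM

Of these two numbers, the value for compound 2 is the higher, and the gap to compound 1 lies beyond the scatter. Compound 2 is therefore the weaker inhibitor of the pair.

The next compound is compound 3 `COc1ccc(/C=C/C(=O)c2ccc(N)cc2)c(OC)c1OC`, not yet measured. It differs from compound 2 by methoxy in place of hydrogen on an aromatic carbon, ortho to two methoxy groups and meta to a large group.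

Among the compounds with values here, no measured pair isolates this change. Compound 3 carries the same methoxy pattern as compound 1, but compound 1 also differs at the amide end, so the value of compound 1 at 510 nM cannot be assigned to the methoxy groups alone. It offers only weak support for a move towards a lower number. A moderate drop in this assay is expected, although a change within the scatter remains possible.

The expected change is a 2.8-fold lower number from compound 2 to compound 3 (0.44 log units; beyond the scatter).

For compound 3 the estimated value is 8000 nM, with an expected range of 1500 nM to 30000 nM.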

Compound 3, half-maximal inhibitory concentration: 8200 nM
Compound 3: the middle estimate sits 1.0-fold (0.01 log units) below what was measured; the range from low to high includes it.
By their numbers in this assay, from the lowest: compound 1; then compound 3; then compound 2.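

In this assay, methoxy in place of hydrogen on an aromatic carbon, ortho to two methoxy groups and meta to a large group, gives a 2.7-fold lower number from compound 2 to compound 3 (0.43 log units; beyond the scatter) and so has a modest effect of its own at this position, beyond the scatter. Hydrogen in place of (1-bromoethenyl)carbonyl on a nitrogen on an aromatic ring gives a 16-fold higher number from compound 1 to compound 3 (1.21 log units; beyond the scatter) and is the larger of the two steps, so the low value of compound 1 goes mainly with the group on the nitrogen and not with the methoxy pattern. No supporting data bear on the reason for either step.

The compounds shown leave open whether the methoxy step carries over when the (1-bromoethenyl)carbonyl group sits on the nitrogen. Also open, from the compounds shown here alone, is how a hydroxy or ethoxy group on this aromatic carbon, or an acetyl or chloroacetyl group on the nitrogen, would compare with the groups seen so far.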